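From Iodophenyl to Bromophenyl in an Ecdysone Agonist Series

A few compounds are considered here, and "the series" means these few. Any claim that something is new, unique, unknown or untested is made for them only; others in the source may bear on it.

In an assay on cells for agonist activity at ecdysone receptor (Bombyx mori), read by a luciferase reporter, with a stated time of 24 h (a lower number here means that less compound is needed, a higher number that more compound is needed for the effect), compound 1 `CC(C)(C)N(NC(=O)c1ccccc1)C(=O)c1ccccc1F` gives 309 nM, compound 2 `CC(C)(C)N(NC(=O)c1ccccc1F)C(=O)c1ccccc1Cl` gives 51.3 nM, and compound 3 `CC(C)(C)N(NC(=O)c1ccccc1I)C(=O)c1ccccc1Cl` gives 1290 nM, the highest of the three numbers. Going by the values given here, the only single-point step measured is a 25-fold higher number from compound 2 to compound 3 (1.40 log units; beyond the scatter), iodo in place of fluoro on an aromatic carbon. Compound 4 `CC(C)(C)N(NC(=O)c1cccc(Br)c1)C(=O)c1ccccc1Cl` differs from compound 3 by 3-bromophenyl in place of 2-iodophenyl on a carbonyl carbon. Among the compounds with values here, no measured compound carries a 3-bromophenyl group, so that part of the change is untested. Removal of the iodo group is expected to lower the number because a 25-fold higher number from compound 2 to compound 3 (1.40 log units; beyond the scatter) accompanied its arrival. Compound 4 is therefore expected to give 200 nM, in a range from 40 nM to 1000 nM. The expected step is a 6.5-fold lower number from compound 3 to compound 4 (0.81 log units; beyond the scatter).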

Compound 4, half-maximal effective concentration: 191 nM
Compound 4: the middle estimate sits 1.0-fold (0.02 log units) above what was measured; the measured number falls inside the stated range.
By their numbers in this assay, from the lowest: compound 2; then compounds 4 and 1 (each within the scatter of the next); then compound 3.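

In this assay, the halogen-bearing phenyl group on this carbonyl carbon need not cost as much as the 2-iodophenyl group did: 3-bromophenyl in its place gives a 6.8-fold lower number from compound 3 to compound 4 (0.83 log units; beyond the scatter). The recovery is only partial, with 3-bromophenyl against 2-fluorophenyl giving a 3.7-fold higher number from compound 2 to compound 4 (0.57 log units; beyond the scatter). No evidence at hand bears on why these numbers differ. The halogen and its place on the ring change together here, so their separate shares remain unresolved. From the compounds shown here alone, how a methoxyphenyl or aminophenyl group would read at this carbonyl carbon also remains open.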